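Swapping a Dichlorophenyl Tail for a Hydroxyphenyl

The source may hold more compounds than are shown below. What is called first, only, known or untested is meant among the compounds shown, and "the series" means these compounds.

Measured so far:
compound 1, `O=C(O)CC(O)(CSCCCCCCc1ccc(Cl)c(Cl)c1)C(=O)O`, 110000 nM
compound 2, `O=C(O)CC(O)(CSCCCCCNc1ccc(Cl)cc1Cl)C(=O)O`, 12000 nM

Of the compounds shown here, two have been measured in an assay on isolated protein for inhibition of ATP-citrate synthase (Rattus norvegicus); on this read-out higher numbers stand for weaker inhibition and lower numbers for stronger inhibition. Compound 1 gives 110000 nM in this assay, and compound 2 gives 12000 nM. Compound 1 stands at the higher of the two numbers, and compound 2 lies below it by a margin beyond the scatter. Among the compounds with values here, the two differ in more than one place, so no single step joins them; their values show only that compound 2 inhibits more strongly than compound 1.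

Compound 3, `O=C(O)CC(O)(CSCCCCCCc1ccc(O)cc1)C(=O)O`, has not yet been measured. It differs from compound 1 in one place: 4-hydroxyphenyl in place of 3,4-dichlorophenyl on a saturated chain carbon, six bonds along the chain from a sulfur. Within the data shown here, both measured compounds carry two chlorines on their ring, so the measured set gives no precedent for a hydroxyphenyl here. Compound 1 already sits at the weak end, and nothing in the data points to a gain from this change. The expected step is a 1.8-fold higher number from compound 1 to compound 3 (0.26 log units; within the scatter), that is, toward a higher number or none beyond the scatter. The estimate for compound 3 in this assay is 200000 nM, within a range from 60000 nM to 700000 nM, and a limit rather than a number is a real possibility.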

Compound 3, inhibition constant: 420000 nM
Beside the measured number, compound 3's estimate is 2.1-fold (0.32 log units) below it; low and high end bracket the measured number.
By their numbers in this assay, from the lowest: compound 2; then compound 1; then compound 3.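

In this assay, within the data shown here, putting 4-hydroxyphenyl in place of 3,4-dichlorophenyl on a saturated chain carbon, six bonds along the chain from a sulfur, gives a 3.8-fold higher number from compound 1 to compound 3 (0.58 log units; beyond the scatter), and this is the first step in the set that can be read at a single place. It shows that this place still responds to a change of the ring group, even though compound 1 already lies at the weak end of the first two compounds, and that the swap from the dichlorophenyl tail to the hydroxyphenyl tail weakens inhibition further rather than leaving it unchanged. Nothing measured here addresses why the number rises with this swap.

The swap removes two chlorines and adds a hydroxyl in the same step, so the compounds shown cannot tell how much of the rise belongs to the loss of the chlorines and how much to the arrival of the hydroxyl. On these data alone, a plain phenyl, a 4-chlorophenyl or a 4-methoxyphenyl at this place would separate these two parts, and how any of them would fall relative to compound 1 and compound 3 remains open.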